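From Fluoro to Cyano: Compound 3 to Compound 4

This account rests on a few compounds, and the source may have more. Where it says the series, first, only, none or still open, it means among the compounds named here.

Measured compounds:
compound 1 `OC[C@@H]1C[C@H](CO)[C@@H]2C(c3ccccc3Cl)=NO[C@H]12`: 33.8 ug/mL
compound 2 `COc1ccc(C2=NO[C@@H]3[C@H](CO)C[C@H](CO)[C@H]23)cc1OC`: a limit, > 50 ug/mL
compound 3 `OC[C@@H]1C[C@H](CO)[C@@H]2C(c3ccc(F)cc3)=NO[C@H]12`: 17.8 ug/mL

In a functional assay on HT-29 cells (Homo sapiens) for cytotoxicity, read by MTT assay, with a stated time of 48 h (a lower number here means a stronger inhibitor, a higher number a weaker inhibitor), compound 3 stands at the low end of the two numbers recorded. Compound 1 is nearest, and the separation between compound 1 and compound 3 falls within the usual scatter, so the two cannot be told apart on these data. For compound 2 this assay reports no number but only a limit, (the limit of > 50 ug/mL in this assay, at which 1 of the 3 values shown sits).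

Compound 4 `N#Cc1ccc(C2=NO[C@@H]3[C@H](CO)C[C@H](CO)[C@H]23)cc1` differs from compound 3 in one place: cyano in place of fluoro on an aromatic carbon. For the measured compounds named here, no pair among the measured compounds shows a change of this kind, so the size of the step must be judged without a direct precedent. The step is expected to be small, a 1.1-fold lower number from compound 3 to compound 4 (0.05 log units; within the scatter), with neither direction favoured beyond the scatter. Compound 4 is accordingly estimated at 16 ug/mL, within a range from 6 ug/mL to 45 ug/mL.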

Compound 4, half-maximal inhibitory concentration: > 50 ug/mL
Compound 4: a limit, no number; the forecaster's own chance of this, stated with the estimate: 12%; middle value at least 3.1-fold (0.49 log units) away from the limit.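

In this assay, cyano in place of fluoro on an aromatic carbon, para to a large group, is not a neutral exchange at this position: the change gives an at least 2.8-fold higher number from compound 3 to compound 4 (0.44 log units; beyond the scatter). For the compounds shown here, this is the first step between measured compounds that differ in one place, so it shows what the earlier compounds could not: the number in this assay responds to the group held on this carbon. The result for compound 4 is a limit and not a number, and compound 2 stands at the same limit: the limit of > 50 ug/mL in this assay, at which 2 of the 4 values shown sit.

The compounds shown leave open how far compound 4 lies beyond its limit, so the full size of the step stays unknown. They also leave open whether an amine or a carboxylic acid on this same carbon would keep the number of compound 3 or move it as the nitrile does.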